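Swapping Methylsulfanyl for Benzylselanyl on the Shared Core

This account rests on a few compounds, and the source may have more. Where it says the series, first, only, none or still open, it means among the compounds named here.

In a functional assay on MCF7 cells (Homo sapiens) for cytotoxicity, read by MTT assay, with a stated time of 72 h (a higher number here means a weaker inhibitor of growth, a lower number a stronger inhibitor of growth), compound 1 `C[Se]/C(=N\C(=O)c1ccco1)NC(=O)c1ccco1` gives 88900 nM. Compound 2 `CS/C(=N\C(=O)c1ccco1)NC(=O)c1ccco1` reaches only the limit of the assay, > 100000 nM, so its standing is known as a limit alone (the limit of > 100000 nM in this assay, at which 1 of the 2 values shown sits). The step of an at least 1.1-fold higher number from compound 1 to compound 2 (0.05 log units; that floor lies within the scatter) is too small to read as a real change. Compound 3 `O=C(/N=C(/NC(=O)c1ccco1)[Se]Cc1ccccc1)c1ccco1` differs from compound 2 by a group of 8 heavy atoms (7 carbon, 1 selenium; one six-membered aromatic ring of carbon only) in place of a group of 2 heavy atoms (1 carbon, 1 sulfur; no ring), on a carbon with a double bond to nitrogen. Selenium returns in compound 3, as in compound 1, which gave 88900 nM, so a number in that region is expected. Compound 3 is therefore estimated at 60000 nM, between 15000 nM and 150000 nM, an expected step of an at least 1.6-fold lower number from compound 2 to compound 3 (0.22 log units; that floor lies within the scatter).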

Compound 3, concentration for total growth inhibition: 58000 nM
Estimate against measurement, compound 3: 1.0-fold (0.01 log units) above; the range from low to high includes it.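

Phenyl in place of hydrogen on the saturated chain carbon bound to a selenium atom gives a 1.5-fold lower number from compound 1 to compound 3 (0.19 log units; within the scatter), so the larger selenium group and the smaller one cannot be told apart in this assay. Set against methylsulfanyl, benzylselanyl gives an at least 1.7-fold lower number from compound 2 to compound 3 (0.23 log units; that floor lies within the scatter), which is only a floor and does not show a real difference. Compound 2 is a limit, not a number: the limit of > 100000 nM in this assay, at which 1 of the 3 values shown sits.

On these data alone, whether selenium itself matters here stays open. So does how an amine or a longer chain would read on this carbon with a double bond to nitrogen.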